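The source may report more compounds than this note shows. Statements on the series, on what has been measured and on what is new or still open speak of the compounds shown alone.

Among the measured compounds shown here, compound 2 `OC[C@@H](O[C@H]1CCCN(Cc2nc3ccccc3[nH]2)[C@H]1c1ccccc1)c1cc(Cl)cc(Cl)c1` stands at the low end of the three numbers so far: in an assay on isolated protein for activation of cGMP-dependent protein kinase 1 (Homo sapiens), read by ADP-Glo, with stated times of 30 min and 2 h, in the presence of a further agent that is not named here (on this read-out higher numbers stand for an effect only at larger amounts of compound and lower numbers for an effect already at smaller amounts), compound 2 gives 4700 nM, while compound 1 `Cc1cc(C(=O)O)ccc1C(C)N1CCC[C@H](O[C@H](CO)c2cc(Cl)cc(Cl)c2)[C@@H]1c1ccccc1` gives 18000 nM and compound 3 `Cc1cc(C(=O)O)ccc1CN1CCC[C@H](O[C@H](CO)c2ccnc(Cl)c2)[C@@H]1c1ccccc1` gives 50000 nM. Compound 4 `O=C(O)c1ccc(CN2CCC[C@H](O[C@H](CO)c3cc(Cl)cc(Cl)c3)[C@@H]2c2ccccc2)c([N+](=O)[O-])c1` differs from compound 2 by 4-carboxy-2-nitrophenyl in place of 1H-benzimidazol-2-yl on a saturated chain carbon bound to an amine nitrogen in a ring. For the measured compounds named here, the only measured step that bears on this change runs the other way: a 3.8-fold lower number from compound 1 to compound 2 (0.58 log units; beyond the scatter), where a carboxy-bearing phenyl group on the ring nitrogen was replaced by the benzimidazolyl group. Compound 4 reinstates a carboxyphenyl group, now carrying a nitro group, and the step from compound 2 to compound 4 is therefore expected to roughly reverse that gain, giving a higher number of about the size seen going from compound 1 to compound 2, here a 3.2-fold higher number from compound 2 to compound 4 (0.50 log units; beyond the scatter). Compound 4 is accordingly expected to come in at 15000 nM in this assay, within a range of 5000 nM to 50000 nM.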

Compound 4, half-maximal effective concentration: 520 nM
For compound 4 the middle estimate is 29-fold (1.46 log units) above the measured one, outside the stated range (below it).
By their numbers in this assay, from the lowest: compound 4; then compound 2; then compound 1; then compound 3.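

At the place on a saturated chain carbon bound to an amine nitrogen in a ring, 1H-benzimidazol-2-yl is not the better group, for in this assay 4-carboxy-2-nitrophenyl brings a 9.0-fold lower number from compound 2 to compound 4 (0.96 log units; beyond the scatter). This opposes any reading of a 3.8-fold lower number from compound 1 to compound 2 (0.58 log units; beyond the scatter) as a general loss from carboxy-bearing phenyl groups, although the group leaving compound 1 also differs from 4-carboxy-2-nitrophenyl in more than one feature. Nothing shown here gives a measured reason for the size or direction of this step. The compounds shown leave open how much of the lower number goes with the nitro group and how much with the carboxylic acid. Also open, going by these compounds, is whether a nitrile, a primary amide or a simple hydrogen in place of the nitro group would hold the number of compound 4 in this assay.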